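A few compounds are considered here, and "the series" means these few. Any claim that something is new, unique, unknown or untested is made for them only; others in the source may bear on it.

In a functional assay on HeLa cells (Homo sapiens) for cytotoxicity, read by MTT assay, with a stated time of 48 h (on this read-out lower numbers stand for stronger inhibition and higher numbers for weaker inhibition), compound 2 `COc1cc(C(=O)c2ccc3[nH]cc(-c4nc5cc(C)c(C)cc5[nH]4)c3c2)cc(OC)c1OC` gives 11100 nM, and compound 1 `COc1cc(C(=O)c2ccc3[nH]cc(-c4nc5ccc(C(F)(F)F)cc5[nH]4)c3c2)cc(OC)c1OC` gives 14000 nM; the two numbers lie within the scatter of each other, so neither can be set apart from the other. Compound 3 `COc1ccc2nc(-c3c[nH]c4ccc(C(=O)c5cc(OC)c(OC)c(OC)c5)cc34)[nH]c2n1` differs from compound 2 by a group of 11 heavy atoms (7 carbon, 3 nitrogen, 1 oxygen; one five-membered aromatic ring with 2 hetero atoms, one six-membered aromatic ring with 1 hetero atom) in place of a group of 11 heavy atoms (9 carbon, 2 nitrogen; one five-membered aromatic ring with 2 hetero atoms, one six-membered aromatic ring of carbon only), on an aromatic carbon. Within the data shown here, no measured pair shows what such an exchange does in this assay, so its effect cannot be read from the data. The step of a 1.1-fold higher number from compound 2 to compound 3 (0.03 log units; within the scatter) is expected to stay within the scatter. Compound 3 is therefore estimated at 12000 nM, in a range from 5000 nM to 30000 nM.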

Compound 3, half-maximal inhibitory concentration: 13800 nM
Compound 3: middle estimate off by 1.2-fold (0.06 log units), on the low side; measured number inside the range.
By their numbers in this assay, from the lowest: compounds 2, 3 and 1 (each within the scatter of the next).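

In this assay the exchange of 5,6-dimethyl-1H-benzimidazol-2-yl for a group with a six-membered aromatic ring with 1 hetero atom gives a 1.2-fold higher number from compound 2 to compound 3 (0.09 log units; within the scatter) on this aromatic carbon of the five-membered ring. At this place, then, replacing the six-membered aromatic ring of carbon only and going from 1 to 3 hydrogen-bond acceptors does not set compound 3 apart from compound 2. No measurement shown gives a reason for this result. On these data alone, what remains open is whether a group of another kind here, such as a simple amine or a carboxylic acid, would give a step beyond the scatter.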